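The source may report more compounds than this note shows. Statements on the series, on what has been measured and on what is new or still open speak of the compounds shown alone.

Measured so far:
Compound 1, `CC(C)Oc1cc(=O)oc2cc(OCc3cccc(Cl)c3)ccc12`: 3%
Compound 2, `COCOc1cc(=O)oc2cc(OCc3cccc(Cl)c3)ccc12`: 23%
Compound 3, `O=C(O)COc1cc(=O)oc2cc(OCc3cccc(Cl)c3)ccc12`: 0%

In an assay on isolated protein (strain Sprague-Dawley) for inhibition of Amine oxidase [flavin-containing] A (Rattus norvegicus), read by spectrophotometry, with a stated time of 5 min, tested at 10 uM (on this read-out higher numbers stand for more inhibition at the one concentration tested (going by the name of the read-out) and lower numbers for less inhibition), compound 3 holds the lowest of the three numbers. The step of a number 3 percentage points lower from compound 1 to compound 3 (within the scatter) lies within the scatter, so compound 3 and compound 1 cannot be told apart, whereas the step of a number 23 percentage points lower from compound 2 to compound 3 (beyond the scatter) lies beyond it. The only step shown to move this read-out is a number 20 percentage points higher from compound 1 to compound 2 (beyond the scatter).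

Compound 4, `CNC(=O)COc1cc(=O)oc2cc(OCc3cccc(Cl)c3)ccc12`, carries the change (methylamino in place of hydroxy on a carbonyl carbon). Among the compounds with values here, no measured step swaps hydroxy for methylamino on a carbonyl carbon, so the guidance is indirect. The step of a number 23 percentage points lower from compound 2 to compound 3 (beyond the scatter) shows that carboxy at this position gave the lowest number of the set, while the step of a number 3 percentage points lower from compound 1 to compound 3 (within the scatter) shows carboxy and isopropyl alike near the floor. Leaving the carboxy behind for methylcarbamoyl is therefore expected to give at most a small step of a number 10 percentage points higher from compound 3 to compound 4 (within the scatter), upward if anything, and not clearly beyond the scatter. Compound 4 is estimated at 10%, with a range from 0% to 30%.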

Compound 4, a percentage reported as inhibition, at one concentration (the size of the read-out at that concentration, not a potency): 11%
The estimate for compound 4 lay 1 percentage points below the measured number; measured number inside the range.
By their numbers in this assay, from the lowest: compounds 3, 1 and 4 (each within the scatter of the next, the first and the last beyond it); then compound 2.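

In this assay, within the data shown here, methylamino in place of hydroxy on a carbonyl carbon gives a step beyond the scatter (a number 11 percentage points higher from compound 3 to compound 4 (beyond the scatter)), so the carbonyl end of this chain can move the read-out, which the earlier compounds did not show. The gain remains partial: methylcarbamoyl in place of methoxy leaves a shortfall beyond the scatter (a number 12 percentage points lower from compound 2 to compound 4 (beyond the scatter)), and the comparison with isopropyl stays within the scatter (a number 8 percentage points higher from compound 1 to compound 4 (within the scatter)), so compound 4 and compound 1 cannot be told apart. The data offer no explanation for these steps.

What the compounds shown leave open is whether a primary amide, a dimethylamide or a methyl ester on the same carbonyl carbon would differ from methylcarbamoyl. Also open, from the compounds shown here alone, is how a longer chain carrying the methylcarbamoyl group would read.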